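Swapping one methoxy for chloro in compound 1

A few compounds are considered here, and "the series" means these few. Any claim that something is new, unique, unknown or untested is made for them only; others in the source may bear on it.

Three compounds measured so far in a functional assay on HeLa cells (Homo sapiens) for cytotoxicity, read by CCK-8 assay, with a stated time of 72 h; on this read-out lower numbers stand for stronger inhibition and higher numbers for weaker inhibition
- Compound 1 (`COc1ccccc1/C=c1/[nH]c(=O)/c(=C\c2ccccc2OC)n(C)c1=O`) gives ("not active" (no number reported))
- Compound 2 (`C=CCn1c(=O)/c(=C\c2ccccc2OC)[nH]c(=O)/c1=C\c1ccccc1OC`) gives (6900 nM)
- Compound 3 (`COc1ccccc1/C=c1/[nH]c(=O)/c(=C\c2ccccc2OC)[nH]c1=O`) gives ("not active" (no number reported))

Compound 1 has no single number to stand on. In this assay compound 1 is recorded as ("not active" (no number reported)), and compound 3 shares that result with ("not active" (no number reported)). Only compound 2 gives a true number, at (6900 nM), so the three compounds offer a single point of reference on the scale.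

The next compound to be tested is compound 4 (`COc1ccccc1/C=c1\c(=O)[nH]/c(=C/c2ccccc2Cl)c(=O)n1C`). It departs from compound 1 in one place only (chloro in place of methoxy on an aromatic carbon), with chloro in place of methoxy on an aromatic carbon, ortho to a large group. The second methoxy group and the rest of the core of compound 1 stay as they are.

Going by the values given here, no measured step shows what this exchange does, so the expectation rests on little. A small step toward stronger inhibition is expected in this assay, and compound 4 may well show no number at all. Among the compounds with values here, the one number available, from compound 2 at (6900 nM), gives a rough guide to where a weak but measurable result could fall. For compound 4 the estimated value is (10000 nM), with an expected range from (3000 nM) to (40000 nM) if a number is reported.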

Compound 4, half-maximal inhibitory concentration: 300 nM
The estimate for compound 4 lay 33-fold (1.52 log units) above the measured number; the measured number lies below the stated range.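

In this assay, going by these compounds alone, compound 1 is recorded as ("not active" (no number reported)) while compound 4 gives (300 nM), so with no number for compound 1, no step between the two can be read. On these data alone, how far the change from 2-methoxyphenyl to 2-chlorophenyl shifts the read-out stays open. No available evidence bears on this result.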